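This account rests on a few compounds, and the source may have more. Where it says the series, first, only, none or still open, it means among the compounds named here.

Measured so far in a functional assay on MDA-MB-231 cells (Homo sapiens) for cytotoxicity, read by MTT assay, with a stated time of 72 h; a higher number here means a weaker inhibitor, a lower number a stronger inhibitor:

Compound 1 `O=C(CN1CCN(c2nnc(Cc3ccncc3)c3ccccc23)CC1)Nc1ccc(Br)cc1`: 19 nM
Compound 2 `O=C(CN1CCN(c2nnc(Cc3ccncc3)c3ccccc23)CC1)Nc1c(F)cccc1F`: 1900 nM

Compound 2 at 1900 nM holds the higher of the two numbers, and its gap to compound 1 lies beyond the scatter. Compound 3 `Cc1ccccc1NC(=O)CN1CCN(c2nnc(Cc3ccncc3)c3ccccc23)CC1` differs from it by 2-methylphenyl in place of 2,6-difluorophenyl on an amide-type nitrogen, with 2-methylphenyl in place of 2,6-difluorophenyl on an amide-type nitrogen. Within the data shown here, one measured step bears on this place: a 100-fold higher number from compound 1 to compound 2 (2.00 log units; beyond the scatter), which is large. It gives no direct reading for 2-methylphenyl, so only a modest move toward a lower number is expected. The expected change is a 2.7-fold lower number from compound 2 to compound 3 (0.43 log units; beyond the scatter) in this assay as estimated here. For compound 3 the estimate is 700 nM with an expected range from 120 nM to 3000 nM as its limits.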

Compound 3, half-maximal inhibitory concentration: 200 nM
Compound 3: the middle estimate sits 3.5-fold (0.54 log units) above what was measured; the range from low to high includes it.
By their numbers in this assay, from the lowest: compound 1; then compound 3; then compound 2.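

In this assay, 2-methylphenyl on the amide-type nitrogen gives a 9.5-fold lower number from compound 2 to compound 3 (0.98 log units; beyond the scatter), so the 2,6-difluorophenyl result does not apply to every group of this kind. It still falls short of 4-bromophenyl, with an 11-fold higher number from compound 1 to compound 3 (1.02 log units; beyond the scatter), which places the three aryl groups at clearly separate levels. Nothing available here accounts for this order. The compounds shown leave open how 4-methylphenyl or 2-bromophenyl would compare, and these two would help separate the identity of the group from where it sits on the ring. An unsubstituted phenyl would provide the missing reference point.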